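A few compounds are considered here, and "the series" means these few. Any claim that something is new, unique, unknown or untested is made for them only; others in the source may bear on it.

Measured in an ADME assay on MT4 cells (Homo sapiens) for cytotoxicity, read by MTT assay; on this read-out lower numbers stand for higher toxicity in this test and higher numbers for lower toxicity in this test:
- compound 1 `Cc1ccc(N(C(=O)c2ccc([N+](=O)[O-])cc2)C(=S)OCCN2C(=O)c3ccccc3C2=O)cc1`: 58000 nM
- compound 2 `O=C1c2ccccc2C(=O)N1CCOC(=S)N(C(=O)c1cccc(Cl)c1Cl)c1ccc(Cl)cc1`: 54000 nM
- compound 3 `Cc1ccc(N(C(=O)c2ccc(F)cc2F)C(=S)OCCN2C(=O)c3ccccc3C2=O)cc1`: 20000 nM

Of these three, compound 3 has the lowest number, and the gaps up to compounds 1 and 2 both lie beyond the scatter. The next compound, compound 4 `Cc1ccc(N(C(=O)c2cccc(Cl)c2Cl)C(=S)OCCN2C(=O)c3ccccc3C2=O)cc1`, carries 2,3-dichlorophenyl in place of 2,4-difluorophenyl on a carbonyl carbon. For the measured compounds named here, no measured step covers this exact change. The nearest is a 2.9-fold lower number from compound 1 to compound 3 (0.46 log units; beyond the scatter), a modest step beyond the scatter, in which 2,4-difluorophenyl replaced 4-nitrophenyl at the same place. Going by the values given here, it shows only that the number can move when this group changes. Compound 2 carries the same 2,3-dichlorophenyl and gives 54000 nM, although it differs from compound 4 at another place. A modest rise in this assay is therefore expected, of about the size of that measured step or somewhat smaller. The expected change is a 2.0-fold higher number from compound 3 to compound 4 (0.30 log units; within the scatter). Compound 4 is estimated at 40000 nM, with an expected range of 18000 nM to 85000 nM.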

Compound 4, half-maximal cytotoxic concentration: 35000 nM
For compound 4 the middle estimate is 1.1-fold (0.06 log units) above the measured one, within the range that was stated.
By their numbers in this assay, from the lowest: compounds 3, 4, 2 and 1 (each within the scatter of the next, the first and the last beyond it).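

In this assay the exchange at this carbonyl carbon gives a 1.8-fold higher number from compound 3 to compound 4 (0.24 log units; within the scatter) and so stays within the scatter, and the other exchange at the same place, a 1.7-fold lower number from compound 1 to compound 4 (0.22 log units; within the scatter) as well, also stays within it. Compound 4 therefore sits within the scatter of both neighbours at this position, so the measured step of a 2.9-fold lower number from compound 1 to compound 3 (0.46 log units; beyond the scatter) is the only one here beyond the scatter, and 2,3-dichlorophenyl cannot be separated from either 2,4-difluorophenyl or 4-nitrophenyl. For the compounds shown here, the compounds also give a first reading of a second place, where methyl in place of chloro on an aromatic carbon gives a 1.5-fold lower number from compound 2 to compound 4 (0.19 log units; within the scatter) and likewise stays within the scatter.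

Nothing available accounts for these readings. Still open, from the compounds shown here alone, is how a phenyl carrying an amine or a carboxylic acid would read on this carbonyl carbon.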